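A Methyl on the Piperidine Ring: Compound 2 to Compound 3

The source may hold more compounds than are shown below. What is called first, only, known or untested is meant among the compounds shown, and "the series" means these compounds.

Measured compounds:
Compound 1 `COc1cc2c(Oc3ccc(NC(=O)c4cn(-c5ccccc5)nn4)cc3F)ccnc2cc1OCCCN1CCCCC1`: 100 nM
Compound 2 `COc1cc2c(Oc3ccc(NC(=O)c4cn(-c5c(Cl)cccc5Cl)nn4)cc3F)ccnc2cc1OCCCN1CCCCC1`: "not determined" (no result reported)

In a functional assay on MKN-45 cells (Homo sapiens) for cytotoxicity, read by MTT assay, with a stated time of 72 h (a higher number here means a weaker inhibitor, a lower number a stronger inhibitor), compound 1 gives 100 nM. Compound 2 has no single number in this assay, so where it stands cannot be said. Compound 3 `COc1cc2c(Oc3ccc(NC(=O)c4cn(-c5c(Cl)cccc5Cl)nn4)cc3F)ccnc2cc1OCCCN1CCC(C)CC1` differs from compound 2 by methyl in place of hydrogen on a saturated ring carbon. Among the measured compounds shown here, no measured step of this kind is available, so little beyond the usual scatter is expected in either direction in this assay. Compound 3 is therefore expected to give about 100 nM, within a range from 30 nM to 400 nM.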

Compound 3, half-maximal inhibitory concentration: 120 nM
Compound 3: middle estimate off by 1.2-fold (0.08 log units), on the low side; the range from low to high includes it.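

In this assay, among the compounds shown here, compound 2 has no single number, so no step from it to compound 3 can be read. The compounds shown leave open what the change from piperidin-1-yl to 4-methylpiperidin-1-yl does to potency. Nothing shown bears on the cause of any result.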